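A few compounds are considered here, and "the series" means these few. Any claim that something is new, unique, unknown or untested is made for them only; others in the source may bear on it.

Working notes on the series, read in a functional assay on HCT-116 cells (Homo sapiens) for cytotoxicity, read by sulforhodamine B assay, with a stated time of 72 h; on this read-out lower numbers stand for stronger inhibition and higher numbers for weaker inhibition. Compound 1 `C=C1C(=O)O[C@@H]2CC(C)=C([C@@H](C)CCCOC(C)=O)[C@@H](OC(=O)CN3CCCC3)[C@H]12` gives 20500 nM, compound 2 `C=C1C(=O)O[C@@H]2CC(C)=C([C@@H](C)CCCOC(C)=O)[C@@H](OC(=O)COc3ccc(C(C)=O)cc3)[C@H]12` gives 40100 nM and compound 3 `C=C1C(=O)O[C@@H]2CC(C)=C([C@@H](C)CCCOC(C)=O)[C@@H](OC(=O)c3cccc(F)c3)[C@H]12` gives 14500 nM. Compound 3 stands level with compound 1 and clear of compound 2 only: a 1.4-fold lower number from compound 1 to compound 3 (0.15 log units; within the scatter), while a 2.8-fold lower number from compound 2 to compound 3 (0.44 log units; beyond the scatter). The remaining pair shows a 2.0-fold higher number from compound 1 to compound 2 (0.29 log units; within the scatter).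

Next in line is compound 4 `C=C1C(=O)O[C@@H]2CC(C)=C([C@@H](C)CCCOC(C)=O)[C@@H](OC(=O)c3ccc(F)cc3)[C@H]12`, with the change 4-fluorophenyl in place of 3-fluorophenyl on a carbonyl carbon. Among the measured compounds shown here, no measured step makes this exact exchange, so the evidence is indirect. The bearing steps replace the whole group on that carbonyl carbon, and even these are small: a 1.4-fold lower number from compound 1 to compound 3 (0.15 log units; within the scatter) and a 2.8-fold lower number from compound 2 to compound 3 (0.44 log units; beyond the scatter). The change in compound 4 is far smaller in kind, so no step beyond the scatter is expected in this assay. For compound 4 the estimated value is 14000 nM, with an expected range of 7000 nM to 29000 nM. This estimate means an expected 1.0-fold lower number from compound 3 to compound 4 (0.02 log units; within the scatter).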

Compound 4, half-maximal inhibitory concentration: 14900 nM
The estimate for compound 4 lay 1.1-fold (0.03 log units) below the measured number; low and high end bracket the measured number.
By their numbers in this assay, from the lowest: compounds 3, 4, 1 and 2 (each within the scatter of the next, the first and the last beyond it).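

In this assay this is the first exchange inside the aryl group on the carbonyl carbon, and going from 3-fluorophenyl to 4-fluorophenyl leaves the number flat (a 1.0-fold higher number from compound 3 to compound 4 (0.01 log units; within the scatter)), so among these two compounds the ring place of the fluorine makes no readable difference. The 4-fluorophenyl group also repeats the standing of the 3-fluorophenyl group against the two other side chains, level with the (pyrrolidin-1-yl)methyl group (a 1.4-fold lower number from compound 1 to compound 4 (0.14 log units; within the scatter)) and clear of the (4-acetylphenoxy)methyl group (a 2.7-fold lower number from compound 2 to compound 4 (0.43 log units; beyond the scatter)). No measurement at hand offers an explanation for this flat step.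

Open, from the compounds shown here alone, is whether an unsubstituted phenyl, a 4-chlorophenyl or a 4-aminophenyl on that carbonyl carbon would stay in the same range. Also open, going by these compounds, is whether a carboxylic acid on the aryl ring would produce a step larger than any seen here.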